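The compounds below may be only part of what the source reports. "The series", "measured", "known", "first", "only" and "open" are said of these compounds alone.

In a functional assay on MGC-803 cells (Homo sapiens) for inhibition, read by MTT assay, with a stated time of 72 h (on this read-out higher numbers stand for weaker inhibition and lower numbers for stronger inhibition), compound 1 `FC(F)(F)c1ccc(CSc2nc(N3CCN(c4ccccc4)CC3)cc(C(F)(F)F)n2)cc1` gives 35200 nM, compound 2 `CC(C)(C)OC(=O)N1CCN(c2cc(C(F)(F)F)nc(SCc3ccc(C(F)(F)F)cc3)n2)CC1` gives 22200 nM, and compound 3 `FC(F)(F)c1ccc(CSc2nc(Sc3ncccn3)cc(C(F)(F)F)n2)cc1` gives 28600 nM. Compound 3 thus stands within the usual scatter of both other compounds, and no order can be drawn between it and either of them. Compound 4 `FC(F)(F)c1ccc(CSc2nc(SC3=NCCS3)cc(C(F)(F)F)n2)cc1` keeps the shared core and differs from compound 3 on a sulfur whose other neighbours are: aromatic carbon. The difference is a group of 5 heavy atoms (3 carbon, 1 nitrogen, 1 sulfur; one five-membered non-aromatic ring with 2 hetero atoms) in place of a group of 6 heavy atoms (4 carbon, 2 nitrogen; one six-membered aromatic ring with 2 hetero atoms), on a sulfur. Among the compounds with values here, only one measured step bears on this, and only indirectly: a 1.6-fold lower number from compound 1 to compound 2 (0.20 log units; within the scatter). It concerns an amine nitrogen in a ring, not the group on the sulfur, so no measurement tests this exchange directly. Still, compound 2 at 22200 nM and compound 3 at 28600 nM carry quite different groups and remain within the scatter of each other, so no change beyond the scatter is expected in this assay. The expected step is a 1.1-fold lower number from compound 3 to compound 4 (0.06 log units; within the scatter). Compound 4 is estimated at 25000 nM, with an expected range from 10000 nM to 50000 nM.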

Compound 4, half-maximal inhibitory concentration: 24500 nM
Beside the measured number, compound 4's estimate is 1.0-fold (0.01 log units) above it; measured number inside the range.
By their numbers in this assay, from the lowest: compounds 2, 4, 3 and 1 (each within the scatter of the next).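

In this assay, within the data shown here, this is the first step measured on the sulfur whose other neighbours are: aromatic carbon, and it comes to a 1.2-fold lower number from compound 3 to compound 4 (0.07 log units; within the scatter). The exchange of a six-membered aromatic ring with 2 hetero atoms for a five-membered non-aromatic ring with 2 hetero atoms therefore leaves the read-out unable to tell the two groups apart, so at this place neither the aromatic ring nor the pyrimidin-2-yl group itself is shown to matter. No measurement at hand speaks to why the two groups read alike.

From the compounds shown here alone, what remains open is whether any group on this sulfur can move the number beyond the scatter, since both groups here are rings with 2 hetero atoms. A carboxylic acid, a primary amine or a longer alkyl chain in that place would test this.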